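Chloro position swap on the aryl group in this series

The source may hold more compounds than are shown below. What is called first, only, known or untested is meant among the compounds shown, and "the series" means these compounds.

The shared core is a fused bicycle carrying a sulfonyl group and an aryl group; compound 1 `COc1ccc(-c2c(S(=O)(=O)c3cc(F)cc(F)c3)cnc3c(F)cccc23)cc1`, compound 2 `Cc1ccc(S(=O)(=O)c2cnc3c(F)cccc3c2-c2ccc(Cl)cc2)cc1F` and compound 3 `O=S(=O)(c1cc(F)cc(F)c1)c1cnc2c(F)cccc2c1-c1cccc(Cl)c1` all have been run in an ADME assay on microsomes from liver (Homo sapiens) for metabolic stability, tested at 2.5 uM; on this read-out lower numbers stand for slow clearance and higher numbers for fast clearance. In this assay compound 1 gives 2.59 mL/min and compound 2 gives 2.2 mL/min, while compound 3 gives 0.64 mL/min, the lowest of the three numbers, with both other compounds beyond the scatter above it. Going by the values given here, the only single-point step among the measured set is a 4.0-fold lower number from compound 1 to compound 3 (0.61 log units; beyond the scatter).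

Compound 4 `O=S(=O)(c1cc(F)cc(F)c1)c1cnc2c(F)cccc2c1-c1ccc(Cl)cc1` has not yet been measured. It differs from compound 3 only in 4-chlorophenyl in place of 3-chlorophenyl on an aromatic carbon. Among the compounds with values here, no measured pair shows exactly this change; the step from compound 1 to compound 3 swaps a different group and so bears on it only loosely, and compound 2, which carries the 4-chlorophenyl group with a different sulfonyl partner, shows a higher number than compound 3 without a single-point link. On that basis a modest rise is expected in this assay, a 1.9-fold higher number from compound 3 to compound 4 (0.27 log units; within the scatter), without confidence that it clears the scatter. The estimate for compound 4 is 1.2 mL/min, within a range of 0.5 mL/min to 2.6 mL/min.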

Compound 4, intrinsic clearance in a liver preparation (reported as CLH), per the amount of preparation that the assay uses: 0.73 mL/min
The estimate for compound 4 lay 1.6-fold (0.22 log units) above the measured number; the measured number falls inside the stated range.
By their numbers in this assay, from the lowest: compounds 3 and 4 (each within the scatter of the next); then compounds 2 and 1 (each within the scatter of the next).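

In this assay the read on chlorine position is a 1.1-fold higher number from compound 3 to compound 4 (0.06 log units; within the scatter) and, with that step inside the scatter, 3-chlorophenyl and 4-chlorophenyl cannot be told apart at this aromatic carbon, opposite the ring nitrogen, in this pair. The sulfonyl side gives the first single-change read at that place, with 3,5-difluorophenyl in place of 3-fluoro-4-methylphenyl on the sulfonyl sulfur, while the 4-chlorophenyl group stays fixed: a 3.0-fold lower number from compound 2 to compound 4 (0.48 log units; beyond the scatter) is a modest step beyond the scatter, so this change registers where the chlorine shift does not. Chloro in place of methoxy at the 4-position of the phenyl group gives a 3.5-fold lower number from compound 1 to compound 4 (0.55 log units; beyond the scatter) and, alongside a 4.0-fold lower number from compound 1 to compound 3 (0.61 log units; beyond the scatter) from the earlier set, the move away from 4-methoxyphenyl reads beyond the scatter with either chlorophenyl group.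

Nothing shown gives a reason for any of these steps. Still open, on these data alone, is whether 3-chlorophenyl paired with 3-fluoro-4-methylphenyl on the sulfonyl sulfur reads the same way in this assay and how an aryl group carrying an amine or a carboxylic acid would read at this place.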